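The source may report more compounds than this note shows. Statements on the series, on what has been measured and on what is new or still open speak of the compounds shown alone.

Measured in a functional assay on B16 cells (Mus musculus) for cytotoxicity, read by MTT assay, with a stated time of 72 h (on this read-out higher numbers stand for weaker inhibition and lower numbers for stronger inhibition), so far:
Compound 1 `COc1ccc(C(=O)c2cc(OC)c(OC)c(OC)c2)cc1NC(=O)/C=C/c1ccc(OC)c(OC)c1` gives 6300 nM.
Compound 2 `COc1ccc(C(=O)c2cc(OC)c(OC)c(OC)c2)cc1NC(=O)/C=C/c1ccc(C(F)(F)F)cc1` gives 100 nM.
Compound 3 `COc1cc(/C=C/C(=O)Nc2cc(C(=O)c3cc(OC)c(OC)c(OC)c3)ccc2OC)ccc1F` gives 16300 nM.

Among these three numbers compound 1 stands second highest. Compound 3 sits a little above it, a 2.6-fold higher number from compound 1 to compound 3 (0.41 log units; beyond the scatter), while compound 2 lies far below it, a 63-fold lower number from compound 1 to compound 2 (1.80 log units; beyond the scatter). Compound 4 `COc1ccc(C(=O)c2cc(OC)c(OC)c(OC)c2)cc1NC(=O)/C=C/c1ccc(N)cc1` has not yet been tested. It differs from compound 1 in one place: 4-aminophenyl in place of 3,4-dimethoxyphenyl on a double-bonded chain carbon bound to a double-bonded chain carbon.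

Among the measured compounds shown here, two measured steps bear on this kind of change, since both alter the same aryl group on the double-bonded chain carbon. When 4-(trifluoromethyl)phenyl replaced 3,4-dimethoxyphenyl the number fell sharply, a 63-fold lower number from compound 1 to compound 2 (1.80 log units; beyond the scatter), and when 4-fluoro-3-methoxyphenyl in turn replaced 4-(trifluoromethyl)phenyl it rose again, a 160-fold higher number from compound 2 to compound 3 (2.21 log units; beyond the scatter). For the measured compounds named here, a single group on that ring thus gave the strongest result seen, but 4-aminophenyl is a different group and no direct precedent exists for it. A step downward in number, smaller than that to compound 2, is expected. This expected step is estimated as a 3.2-fold lower number from compound 1 to compound 4 (0.50 log units; beyond the scatter). Compound 4 is therefore estimated at 2000 nM, with a range of 300 nM to 12000 nM.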

Compound 4, half-maximal inhibitory concentration: 7900 nM
Estimate against measurement, compound 4: 4.0-fold (0.60 log units) below; the measured number falls inside the stated range.
By their numbers in this assay, from the lowest: compound 2; then compounds 1 and 4 (each within the scatter of the next); then compound 3.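

In this assay, 4-aminophenyl and 3,4-dimethoxyphenyl cannot be told apart at this position (a 1.3-fold higher number from compound 1 to compound 4 (0.10 log units; within the scatter)), so having just one group on this ring is not enough to give a low number. Amino does not stand in for trifluoromethyl on the same ring (a 79-fold higher number from compound 2 to compound 4 (1.90 log units; beyond the scatter)), which makes the group itself, and not merely the loss of the methoxy groups, what separates compound 2 from compound 1 and compound 4. Among the compounds shown here, compound 4 also gives a modestly lower number than the fluoro-bearing ring of compound 3 (a 2.1-fold lower number from compound 3 to compound 4 (0.31 log units; beyond the scatter)), a small gap beside the one to compound 2, and nothing available explains these differences.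

For the compounds shown here, compound 2 remains the only low number in this set, resting on a single group. On these data alone, it remains open whether 4-chlorophenyl, 4-cyanophenyl or a ring carrying a carboxylic acid would give a number close to that of compound 2 or close to those of the other three compounds.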